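The source may hold more compounds than are shown below. What is called first, only, known or untested is meant among the compounds shown, and "the series" means these compounds.

Three compounds share one core and differ only in the group on an aromatic nitrogen: compound 1 (`Cc1ccc(C(=O)Nc2cccc(C(F)(F)F)c2)cc1-c1ccc2c(-c3cnn(C)c3)n[nH]c2c1`), compound 2 (`Cc1ccc(C(=O)Nc2cccc(C(F)(F)F)c2)cc1-c1ccc2c(-c3cnn(C(C)C)c3)n[nH]c2c1`) and compound 3 (`Cc1ccc(C(=O)Nc2cccc(C(F)(F)F)c2)cc1-c1ccc2c(-c3cnn(C4CC4)c3)n[nH]c2c1`). In a functional assay on KG-1 cells (Homo sapiens) for antiproliferative activity, read by CCK-8 assay, with a stated time of 72 h (on this read-out lower numbers stand for stronger inhibition and higher numbers for weaker inhibition), compound 1 gives (65.7 nM), compound 2 gives (452 nM) and compound 3 gives (108 nM). Compound 3 therefore stands close to compound 1 and clearly apart from compound 2.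

Compound 4 (`Cc1ccc(C(=O)Nc2cccc(C(F)(F)F)c2)cc1-c1ccc2c(-c3cnn(CC(=O)N(C)C)c3)n[nH]c2c1`) carries (dimethylcarbamoyl)methyl in place of cyclopropyl on an aromatic nitrogen. Changes at this same nitrogen have already shifted the number by a 6.9-fold higher number from compound 1 to compound 2 (0.84 log units; beyond the scatter) and by a 4.2-fold lower number from compound 2 to compound 3 (0.62 log units; beyond the scatter) while a 1.6-fold higher number from compound 1 to compound 3 (0.22 log units; within the scatter) stayed small. Among the measured compounds shown here, none of the measured compounds carries a chain like the one entering here, so these steps give only a rough idea of size. A step no larger than the modest ones is expected in this assay with a slight lean towards a higher number, and one within the scatter is the most likely outcome. The expected change is a 1.6-fold higher number from compound 3 to compound 4 (0.20 log units; within the scatter) by this estimate. The estimate for compound 4 is 170 nM with an expected range from 55 nM to 520 nM as the likely span.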

Compound 4, half-maximal inhibitory concentration: 441 nM
Beside the measured number, compound 4's estimate is 2.6-fold (0.41 log units) below it, and the stated range covers the measured number.
By their numbers in this assay, from the lowest: compounds 1 and 3 (each within the scatter of the next); then compounds 4 and 2 (each within the scatter of the next).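

In this assay the (dimethylcarbamoyl)methyl chain shows that an open chain carrying an amide can lose much of the activity at this nitrogen, with a 4.1-fold higher number from compound 3 to compound 4 (0.61 log units; beyond the scatter) and a 6.7-fold higher number from compound 1 to compound 4 (0.83 log units; beyond the scatter) on the way from the two best compounds. With a 1.0-fold lower number from compound 2 to compound 4 (0.01 log units; within the scatter) as its step from the isopropyl compound, this chain reads the same as isopropyl, so two very different groups end up level here. Nothing measured here explains the loss.

The compounds shown leave open whether the loss follows the amide or the length of the chain. A plain ethyl or propyl chain, and a chain ending in a dimethylamine or a carboxylic acid, would help to separate the two.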